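Hydroxyphenyl positional isomers on a shared pyridine-type core

The source may hold more compounds than are shown below. What is called first, only, known or untested is meant among the compounds shown, and "the series" means these compounds.

Three tris(hydroxyphenyl) compounds have been run in a functional assay on T47D cells (Homo sapiens) for cytotoxicity, read by CCK-8 assay, with a stated time of 4 days; on this read-out higher numbers stand for weaker inhibition and lower numbers for stronger inhibition. Compound 1 `Oc1ccc(-c2cc(-c3cccc(O)c3)nc(-c3cccc(O)c3)c2)cc1` gives 2230 nM in this assay. Compound 2 `Oc1cccc(-c2cc(-c3ccccc3O)cc(-c3cccc(O)c3)n2)c1` gives 4570 nM, and compound 3 `Oc1ccc(-c2cc(-c3ccccc3O)cc(-c3ccccc3O)n2)cc1` gives 960 nM, the lowest number of the three, with its steps to compound 1 and compound 2 both beyond the usual scatter.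

Compound 1 and compound 2 differ in one place, (4-hydroxyphenyl in place of 2-hydroxyphenyl on an aromatic carbon), and the change produced a 2.0-fold lower number from compound 2 to compound 1 (0.31 log units; beyond the scatter). The cores of compound 2 and compound 3 differ in more than one place, and that difference is not broken down here.

Compound 4 `Oc1ccc(-c2cc(-c3ccccc3O)cc(-c3ccc(O)cc3)n2)cc1` has not yet been measured. It differs from compound 3 in one place, (4-hydroxyphenyl in place of 2-hydroxyphenyl on an aromatic carbon). Among the measured compounds shown here, this is the same kind of change as the one from compound 2 to compound 1, but not the same: in compound 1 the entering group sits opposite the ring nitrogen and meta to two 3-hydroxyphenyl groups, whereas in compound 4 it sits next to the ring nitrogen, meta to a 2-hydroxyphenyl group and meta to a 4-hydroxyphenyl group.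

For the measured compounds named here, the expectation for compound 4 is a step of about a 1.9-fold lower number from compound 3 to compound 4 (0.28 log units; within the scatter) in this assay, resting on the single earlier example, because compound 1 showed a 2.0-fold lower number from compound 2 to compound 1 (0.31 log units; beyond the scatter). The difference in surroundings widens the uncertainty. Compound 4 is estimated at 500 nM in this assay, expected to fall between 250 nM and 1000 nM.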

Compound 4, half-maximal inhibitory concentration: 5350 nM
Estimate against measurement, compound 4: 11-fold (1.03 log units) below, outside the stated range (above it).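

In this assay, placing 4-hydroxyphenyl where 2-hydroxyphenyl stood next to the ring nitrogen gives a 5.6-fold higher number from compound 3 to compound 4 (0.75 log units; beyond the scatter), the opposite direction to the earlier example of this change, a 2.0-fold lower number from compound 2 to compound 1 (0.31 log units; beyond the scatter). Among the compounds shown here, the change therefore does not carry from one core to the other with a fixed direction or size, and the two results differ by more than repeat measurements would explain: the same change on two cores in this assay, a 2.0-fold lower number (0.31 log units; beyond the scatter) from compound 2 to compound 1 and a 5.6-fold higher number (0.75 log units; beyond the scatter) from compound 3 to compound 4, 11-fold (1.06 log units) apart, beyond the scatter of two such steps This pair shows that the outcome of the change depends on its setting in these compounds, but with only two examples it does not show which feature of that setting matters, whether the place on the shared core or the other hydroxyphenyl groups present, and it offers no rule for predicting a further core.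

Still open, from the compounds shown here alone, is how the remaining placements of 2-hydroxyphenyl, 3-hydroxyphenyl and 4-hydroxyphenyl around the shared core would behave in this assay, and whether further single changes would follow either of the two steps. The compounds shown also leave open whether the hydroxyl itself is needed, a question that a methoxy group, an amine or a carboxylic acid at the same place on a phenyl ring would address.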